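The compounds below may be only part of what the source reports. "The series", "measured", "known", "first", "only" and "open" are said of these compounds alone.

Compound 1 `Cc1nc(-c2cccnc2)sc1-c1nnc(Cc2ccccc2)o1` gives only a limit in an ADME assay on PANC-1 cells (Homo sapiens) for cytotoxicity, read by MTT assay; a higher number here means that more compound is tolerated, a lower number that less compound is tolerated: > 100 ug/mL.
Compound 2 `Cc1nc(-c2cccnc2)sc1-c1nnc(-c2ccccc2Cl)o1` gives only a limit: > 100 ug/mL.
Compound 3 `Cc1cccc(-c2nnc(-c3sc(-c4cccnc4)nc3C)o2)c1` gives only a limit: > 100 ug/mL.

Compound 2 stands where every measured compound stands, at the limit of > 100 ug/mL in this assay, at which 3 of the 3 values shown sit. From it the account turns to compound 4 `Cc1nc(-c2cccnc2)sc1-c1nnc(-c2ccc(O)cc2)o1`, which differs by 4-hydroxyphenyl in place of 2-chlorophenyl on an aromatic carbon. The measured steps are all unreadable: a step that the two limits leave unreadable from compound 1 to compound 2, a step that the two limits leave unreadable from compound 1 to compound 3 and a step that the two limits leave unreadable from compound 2 to compound 3. None of them bears readably on the step to compound 4, and no measured change in this set brings in a 4-hydroxyphenyl. Compound 4 is therefore expected to remain at the same limit, with the step that the limit leaves unreadable from compound 2 to compound 4 expected to be none beyond the scatter. The estimate for compound 4 in this assay is 150 ug/mL, within 80 ug/mL to 300 ug/mL.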

Compound 4, half-maximal cytotoxic concentration: > 100 ug/mL
Compound 4 gave a limit, no number (the forecaster's own chance of this, stated with the estimate: 85%); the middle value lies beyond the limit too.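

No step from compound 1, compound 2 or compound 3 to compound 4 can be read, as all four compounds share a single limit: the limit of > 100 ug/mL in this assay, at which 4 of the 4 values shown sit.

The compounds shown leave open how far each lies beyond that limit, and so whether exchanging these groups on the shared core changes the result in this assay at all.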